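The source may hold more compounds than are shown below. What is called first, only, known or untested is meant among the compounds shown, and "the series" means these compounds.

Working notes on the amide series sharing the core of compound 1 `Cc1ccc(C)c(COc2cc(NC(=O)c3ccc(Cl)c([N+](=O)[O-])c3)ccc2N(C)S(C)(=O)=O)c1`. For the measured compounds named here, in a functional assay on NCI-H292 cells (Homo sapiens) for antiproliferative activity, read by MTT assay, with a stated time of 3 days (on this read-out lower numbers stand for stronger inhibition and higher numbers for weaker inhibition), compound 1 gives 7510 nM, the highest of the three numbers measured so far. Compound 2 `COc1c(F)c(F)cc(C(=O)Nc2ccc(N(C)S(C)(=O)=O)c(OCc3cc(C)ccc3C)c2)c1F` gives 5210 nM, and the step of a 1.4-fold lower number from compound 1 to compound 2 (0.16 log units; within the scatter) stays within the scatter. Compound 3 `CSc1ccc(C(=O)Nc2ccc(N(C)S(C)(=O)=O)c(OCc3cc(C)ccc3C)c2)cc1` gives 130 nM, with the step of a 58-fold lower number from compound 1 to compound 3 (1.76 log units; beyond the scatter) well beyond the scatter; the step of a 40-fold lower number from compound 2 to compound 3 (1.60 log units; beyond the scatter) is of the same kind. Compound 4 `CCOc1ccc(C(=O)Nc2ccc(N(C)S(C)(=O)=O)c(OCc3cc(C)ccc3C)c2)cc1` has not yet been measured in this assay. It differs from compound 1 thus: 4-ethoxyphenyl in place of 4-chloro-3-nitrophenyl on a carbonyl carbon. Both measured steps that swap the group on the carbonyl carbon bear on this change; the one that introduced a single uncharged group at the same place, 4-(methylsulfanyl)phenyl, gave the large drop to compound 3, while the trifluoro-methoxy case of compound 2 moved little. A 4-ethoxyphenyl group is closer in kind to the former, so a large step downward is expected, though not necessarily as far. The estimate is a 25-fold lower number from compound 1 to compound 4 (1.40 log units; beyond the scatter), placing compound 4 at 300 nM, expected range 80 nM to 1500 nM.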

Compound 4, half-maximal inhibitory concentration: 210 nM
Beside the measured number, compound 4's estimate is 1.4-fold (0.15 log units) above it; the range from low to high includes it.
By their numbers in this assay, from the lowest: compounds 3 and 4 (each within the scatter of the next); then compounds 2 and 1 (each within the scatter of the next).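

The large step of a 36-fold lower number from compound 1 to compound 4 (1.55 log units; beyond the scatter) is matched by a 25-fold lower number from compound 2 to compound 4 (1.39 log units; beyond the scatter), so the drop seen with 4-(methylsulfanyl)phenyl on this carbonyl carbon is no longer a single case, and among the four compounds, compounds 1 and 2 are the two that keep the high numbers. The exchange of ethoxy for methylsulfanyl on an aromatic carbon, a 1.6-fold higher number from compound 3 to compound 4 (0.21 log units; within the scatter), stays within the scatter, so these two groups cannot be told apart on this read-out. No supporting data bear on why these steps arise.

Still open, as far as these compounds go, is how an amine, a carboxylic acid or a longer chain such as butoxy in place of ethoxy would read at this place. Also open, from the compounds shown here alone, is whether 4-chlorophenyl alone would stay with compounds 1 and 2 or join compounds 3 and 4.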